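The source may hold more compounds than are shown below. What is called first, only, known or untested is meant among the compounds shown, and "the series" means these compounds.

Measured compounds:
- compound 1 `CC(=O)Nc1cc(NC(=O)NCCCCC(c2ccc(F)cc2)c2ccc(F)cc2)ccc1Cl`: 609 nM
- compound 2 `O=C(NCCCCC(c1ccc(F)cc1)c1ccc(F)cc1)Nc1ccc(Cl)cc1C(F)(F)F`: "not determined" (no result reported)
- compound 3 `Cc1ccc(C(CCCCNC(=O)Nc2ccc(Cl)c(C(F)(F)F)c2)c2ccc(C)cc2)cc1`: "not determined" (no result reported)

Going by the values given here, in an ADME assay on isolated protein for inhibition of sodium-dependent dopamine transporter (Homo sapiens) (a higher number here means a weaker inhibitor, a lower number a stronger inhibitor), compound 1 gives 609 nM, the only number in the set. For compound 2 the outcome in this assay is "not determined" (no result reported), and for compound 3 the outcome in this assay is likewise "not determined" (no result reported); compound 3 therefore stands on no number at all, and one further compound shares that position. Among the compounds with values here, no pair of measured compounds differs in one place, so no measured step is available.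

Compound 4 `Cc1ccc(C(CCCCNC(=O)Nc2ccc(Cl)cc2)c2ccc(C)cc2)cc1` arises from compound 3 by hydrogen in place of trifluoromethyl on an aromatic carbon. With compound 3 lacking a number, the size and direction of this step cannot be read from the data; the expectation rests only on compound 1 at 609 nM as the sole reference for the shared core. Compound 4 is expected to give about 600 nM in this assay, within a range of 150 nM to 2500 nM.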

Compound 4, inhibition constant: 535 nM
Estimate against measurement, compound 4: 1.1-fold (0.05 log units) above; the range from low to high includes it.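

Compound 3 has no number, so the step from it to compound 4 cannot be read. The compounds shown leave open whether going from 4-chloro-3-(trifluoromethyl)phenyl to 4-chlorophenyl changes the result in this assay at all. No supporting data bear on this result.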